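The source may report more compounds than this note shows. Statements on the series, on what has been measured and on what is new or still open speak of the compounds shown alone.

In a functional assay on A549 cells (Homo sapiens) for antiproliferative activity, read by MTT assay, with a stated time of 72 h (on this read-out higher numbers stand for weaker inhibition and lower numbers for stronger inhibition), compound 1 `O=C(Nc1ccccc1)C(Cl)Cl`, which has no group on the aromatic ring, gives 130000 nM. Placing chloro in place of hydrogen on an aromatic carbon yields compound 2 `O=C(Nc1ccc(Cl)cc1)C(Cl)Cl`, which gives 20400 nM, and this is a 6.4-fold lower number from compound 1 to compound 2 (0.80 log units; beyond the scatter). The bromo counterpart, compound 3 `O=C(Nc1ccc(Br)cc1)C(Cl)Cl`, gives 13700 nM, and this is a 9.5-fold lower number from compound 1 to compound 3 (0.98 log units; beyond the scatter). Between the two halogen-bearing compounds there is a 1.5-fold lower number from compound 2 to compound 3 (0.17 log units; within the scatter), so compound 3 stands level with compound 2, and both stand well under compound 1.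

Compound 4 `COc1ccc(NC(=O)C(Cl)Cl)cc1` has methoxy in place of bromo on an aromatic carbon, (methoxy in place of bromo on an aromatic carbon). Within the data shown here, no measured step involves methoxy, so the evidence is indirect. Among the measured compounds shown here, the two steps from compound 1 show what chloro and bromo do at this position, while the step between compound 2 and compound 3 shows only that these two groups cannot be told apart here. Methoxy may or may not share their gain, so a rise from compound 3 is expected, of modest size and probably stopping short of compound 1, which gives 130000 nM. The expected step is a 3.3-fold higher number from compound 3 to compound 4 (0.52 log units; beyond the scatter). For compound 4 the estimated value is 45000 nM, within an expected range of 14000 nM to 130000 nM.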

Compound 4, half-maximal inhibitory concentration: 80900 nM
Estimate against measurement, compound 4: 1.8-fold (0.25 log units) below; measured number inside the range.
By their numbers in this assay, from the lowest: compounds 3 and 2 (each within the scatter of the next); then compounds 4 and 1 (each within the scatter of the next).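

In this assay, the new result shows that the gain seen with chloro and bromo does not extend to every group on this aromatic carbon: methoxy in place of bromo gives (a 5.9-fold higher number from compound 3 to compound 4 (0.77 log units; beyond the scatter)) and methoxy in place of chloro gives (a 4.0-fold higher number from compound 2 to compound 4 (0.60 log units; beyond the scatter)). Methoxy in place of hydrogen gives (a 1.6-fold lower number from compound 1 to compound 4 (0.21 log units; within the scatter)), so compound 4 stands level with compound 1, and of the three groups placed here, methoxy alone brings no gain that can be read. This position therefore separates the groups it carries, which the two halogens, level with each other, could not show, though nothing measured here bears on why methoxy parts from them.

The compounds shown leave open whether other groups at this position, such as an amine, a nitrile, trifluoromethyl or a longer alkoxy chain, would follow the halogens or methoxy. They also leave open whether fluoro or iodo would share the gain of chloro and bromo, and whether either halogen would keep that gain on another carbon of the ring.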